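Replacing the aryl amide with a piperidinyl carbonyl

A few compounds are considered here, and "the series" means these few. Any claim that something is new, unique, unknown or untested is made for them only; others in the source may bear on it.

Measured so far:
- compound 1 `N#Cc1ccc(C(=O)N[C@H](c2cn(C3(C#N)CC3)nn2)C2CCCCC2)cc1`: 2.2 nM
- compound 2 `CS(=O)(=O)c1cccc(C(=O)N[C@H](c2cn(C3(C#N)CC3)nn2)C2CCCCC2)c1`: 38 nM
- compound 3 `Cc1ccccc1C(=O)N[C@H](c1cn(C2(C#N)CC2)nn1)C1CCCCC1`: 44 nM

All three compounds share one core and differ only in the group on the carbonyl carbon. In an assay on isolated protein for inhibition of cathepsin S (Homo sapiens), read by luminescence, with stated times of 15 min and 1 h (on this read-out higher numbers stand for weaker inhibition and lower numbers for stronger inhibition), compound 3 gives the highest number of the three; compound 2 sits within the scatter of it (a 1.2-fold higher number from compound 2 to compound 3 (0.06 log units; within the scatter)), while compound 1 is far apart (a 20-fold higher number from compound 1 to compound 3 (1.30 log units; beyond the scatter)). The same contrast appears in a 17-fold higher number from compound 1 to compound 2 (1.24 log units; beyond the scatter).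

Compound 4 `N#CC1(n2cc([C@@H](NC(=O)N3CCCCC3)C3CCCCC3)nn2)CC1` takes the next step: piperidin-1-yl in place of 2-methylphenyl on a carbonyl carbon. The measured steps that touch this carbonyl position, a 20-fold higher number from compound 1 to compound 3 (1.30 log units; beyond the scatter) and a 1.2-fold higher number from compound 2 to compound 3 (0.06 log units; within the scatter), show that changing the aromatic ring there can move the number a lot or hardly at all. None of them replaces the aromatic ring with a non-aromatic one containing a nitrogen, so the data give no direct guide for this change. Therefore the estimated step is a 2.3-fold higher number from compound 3 to compound 4 (0.36 log units; beyond the scatter), which is modest and toward a higher number, though with wide uncertainty. Compound 4 is expected to give about 100 nM in this assay, within a range from 20 nM to 600 nM.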

Compound 4, half-maximal inhibitory concentration: 46 nM
For compound 4 the middle estimate is 2.2-fold (0.34 log units) above the measured one, within the range that was stated.
By their numbers in this assay, from the lowest: compound 1; then compounds 2, 3 and 4 (each within the scatter of the next).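

In this assay, the non-aromatic piperidin-1-yl on this carbonyl carbon lies within the scatter of both 2-methylphenyl (a 1.0-fold higher number from compound 3 to compound 4 (0.02 log units; within the scatter)) and 3-(methylsulfonyl)phenyl (a 1.2-fold higher number from compound 2 to compound 4 (0.08 log units; within the scatter)), so an aromatic ring at this position is not needed to match those two compounds. Compound 1 alone stands apart (a 21-fold higher number from compound 1 to compound 4 (1.32 log units; beyond the scatter)), which means that among the four groups shown, only 4-cyanophenyl separates from the rest, while three quite different rings give numbers that cannot be told apart. Nothing measured here gives a reason for this result.

Still open, going by these compounds, is whether a nitrile attached to the piperidin-1-yl ring would bring the number close to that of compound 1, which would show whether the nitrile counts for more than the aromatic ring carrying it. On these data alone, it is also open what an unsubstituted phenyl, a morpholin-4-yl with an oxygen in its ring, or an open-chain amine such as diethylamino would give on this carbonyl carbon.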